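Swapping Naphthalen-1-yl for Pentan-3-yl: Cytotoxicity Outlook

The source may report more compounds than this note shows. Statements on the series, on what has been measured and on what is new or still open speak of the compounds shown alone.

Measured so far:
compound 1 `COc1ccc(Oc2ccc3c(NCCCNCc4cc(F)ccc4OC)ccnc3c2)cc1`: 7000 nM
compound 2 `COc1ccc(F)cc1CNCCCNc1ccnc2cc(Cc3ccc(F)cc3)ccc12`: 3530 nM
compound 3 `COc1ccc(F)cc1CNCCCNc1ccnc2cc(-c3cccc4ccccc34)ccc12`: 16000 nM

In an ADME assay on HepG2 cells (Homo sapiens) for cytotoxicity, read by luminescence, CellTiter-Glo and ATP content, with a stated time of 72 h (on this read-out higher numbers stand for an effect only at larger amounts of compound and lower numbers for an effect already at smaller amounts), compound 3 gives 16000 nM, the highest of the three numbers. Compound 1, at 7000 nM, is the nearest: a 2.3-fold higher number from compound 1 to compound 3 (0.36 log units; beyond the scatter). Compound 2, at 3530 nM, is the furthest: a 4.5-fold higher number from compound 2 to compound 3 (0.66 log units; beyond the scatter). Among the compounds with values here, the one remaining step, a 2.0-fold lower number from compound 1 to compound 2 (0.30 log units; within the scatter), lies within the scatter.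

Compound 4 `CCC(CC)c1ccc2c(NCCCNCc3cc(F)ccc3OC)ccnc2c1` has not yet been measured. It differs from compound 3 by pentan-3-yl in place of naphthalen-1-yl on an aromatic carbon. Within the data shown here, the steps that bear on this change are the two that replaced a group at the same aromatic carbon, a 2.3-fold higher number from compound 1 to compound 3 (0.36 log units; beyond the scatter) and a 4.5-fold higher number from compound 2 to compound 3 (0.66 log units; beyond the scatter), both modest and both raising the number when naphthalen-1-yl entered. Among the measured compounds shown here, no measured step puts a chain without a ring at this position, so the direction is uncertain; a modest step downward is expected, on the strength of compound 1 at 7000 nM and compound 2 at 3530 nM both sitting below compound 3. Compound 4 is therefore estimated at 9000 nM, between 3500 nM and 22000 nM, which means an expected step of a 1.8-fold lower number from compound 3 to compound 4 (0.25 log units; within the scatter).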

Compound 4, half-maximal effective concentration: 7860 nM
Estimate against measurement, compound 4: 1.1-fold (0.06 log units) above; measured number inside the range.
By their numbers in this assay, from the lowest: compounds 2, 1 and 4 (each within the scatter of the next, the first and the last beyond it); then compound 3.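

In this assay, within the data shown here, pentan-3-yl puts a chain with no ring on this aromatic carbon for the first time, and removing the two aromatic rings of naphthalen-1-yl gives a 2.0-fold lower number from compound 3 to compound 4 (0.31 log units; beyond the scatter). The number also stays close to that of a ring-bearing group at this position, with a 1.1-fold higher number from compound 1 to compound 4 (0.05 log units; within the scatter), while the comparison with 4-fluorobenzyl gives a 2.2-fold higher number from compound 2 to compound 4 (0.35 log units; beyond the scatter); among these compounds, therefore, a ring at this carbon is not required for a number in this range, and only naphthalen-1-yl stands apart from pentan-3-yl on the high side. Nothing available gives a reason for these steps.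

Since pentan-3-yl is the only chain shown here, it remains open whether a methyl group or a longer chain would give a similar number. As far as these compounds go, the effect of an amine or a carboxylic acid on this carbon also remains open.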